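Indole amide series: ring swap on the piperazinone carbon

The source may hold more compounds than are shown below. What is called first, only, known or untested is meant among the compounds shown, and "the series" means these compounds.

Going by the values given here, compound 1 `COc1ccc2[nH]c(C(=O)N3CC(=O)N(Cc4ccccc4)[C@@H](N4[C@H](C)CCC[C@@H]4C)C3)cc2c1` gives 0.112 h in an ADME assay on microsomes from liver (Homo sapiens) for metabolic stability, with a stated time of 30 min, tested at 1 uM (on this read-out lower numbers stand for a shorter-lived compound and higher numbers for a longer-lived compound), the lowest of the two numbers so far. Compound 2 `COc1ccc2[nH]c(C(=O)N3CC(=O)N(Cc4ccccc4)[C@@H](CN4CCN(c5ccc(F)cc5)CC4)C3)cc2c1` gives 0.457 h in this assay, a gap beyond the scatter. Compound 3 `COc1ccc2[nH]c(C(=O)N3CC(=O)N(Cc4ccccc4)[C@@H](CN4CCc5ccccc5C4)C3)cc2c1` carries the change ((1,2,3,4-tetrahydroisoquinolin-2-yl)methyl in place of 2,6-dimethylpiperidin-1-yl on a saturated ring carbon), bringing in one six-membered aromatic ring of carbon only where compound 1 had two defined stereocentres. Among the compounds with values here, no measured step covers this change. The step of a 2.2-fold higher number from compound 1 to compound 3 (0.35 log units; beyond the scatter) is expected to be a small rise, near the edge of the scatter. Compound 3 is expected to give 0.25 h, with a range from 0.11 h to 0.55 h.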

Compound 3, half-life: 0.617 h
Compound 3: the middle estimate sits 2.5-fold (0.39 log units) below what was measured, and the stated range ends below it.
By their numbers in this assay, from the lowest: compound 1; then compounds 2 and 3 (each within the scatter of the next).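

On the saturated ring carbon, (1,2,3,4-tetrahydroisoquinolin-2-yl)methyl in place of 2,6-dimethylpiperidin-1-yl gives a 5.5-fold higher number from compound 1 to compound 3 (0.74 log units; beyond the scatter) in this assay and shows that a second ring system at this position is compatible with a longer half-life. Compound 3 lies within the scatter of compound 2, which carries a different group on the same carbon. Nothing available bears on the cause of this step.

The step changes the aromatic ring, the methyl link and the two defined stereocentres together, and these remain unseparated. Also open, going by these compounds, is what this assay gives for an unsubstituted piperidin-1-ylmethyl group on this carbon.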